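The source may hold more compounds than are shown below. What is called first, only, known or untested is meant among the compounds shown, and "the series" means these compounds.

Working notes on the series, all read in a functional assay on HL-60 cells (Homo sapiens) for inhibition, read by MTT assay, with a stated time of 48 h, tested at 10 uM; on this read-out lower numbers stand for less inhibition of growth and higher numbers for more inhibition of growth at the one concentration tested. Compound 1 (`Cc1cc(=O)c2c(O)c(CN(C(C)C)C(C)C)c(O)c([C@H]3CCN(C)C[C@H]3O)c2o1`) gives 21%, compound 2 (`CN1CC[C@H](c2c(O)cc(O)c3c(=O)cc(/C=C/c4ccccc4)oc23)[C@H](O)C1`) gives 91%, and compound 3 (`CN1CC[C@H](c2c(O)cc(O)c3c(=O)cc(/C=C/c4ccc(Cl)cc4)oc23)[C@H](O)C1`) gives 58%. Compound 3 therefore stands second highest of the three numbers, below compound 2 and above compound 1, with both gaps beyond the scatter.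

Compound 4 (`CN1CC[C@H](c2c(O)cc(O)c3c(=O)cc(/C=C/c4ccccc4F)oc23)[C@H](O)C1`) is the next to read. Its difference from compound 3 is 2-fluorophenyl in place of 4-chlorophenyl on a double-bonded chain carbon bound to a double-bonded chain carbon. Among the measured compounds shown here, the 4-chlorophenyl is lost, and no measured compound carries 2-fluorophenyl. For the measured compounds named here, the only measured step that bears on this change is a number 33 percentage points lower from compound 2 to compound 3 (beyond the scatter), with chloro in place of hydrogen on an aromatic carbon. On these data alone, that single large step suggests a number for compound 4 above that of compound 3, though short of the full size of that step, and the fluoro placement remains untested. The expected step, upward and of moderate size, is a number 14 percentage points higher from compound 3 to compound 4 (beyond the scatter). For compound 4 the estimated value is 72%, with an expected range from 48% to 93%.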

Compound 4, percent growth inhibition at one concentration: 62%
For compound 4 the middle estimate is 10 percentage points above the measured one, and the stated range covers the measured number.
By their numbers in this assay, from the lowest: compound 1; then compounds 3 and 4 (each within the scatter of the next); then compound 2.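

In this assay the exchange of 4-chlorophenyl for 2-fluorophenyl gives a number 4 percentage points higher from compound 3 to compound 4 (within the scatter) and so does not separate these two substituted phenyl groups. A fluoro group on the phenyl ring gives a number 29 percentage points lower from compound 2 to compound 4 (beyond the scatter) and so is a second halogen step, after chloro, that reads lower than the unsubstituted phenyl of compound 2, a pattern resting on compound 3 and compound 4 alone. No measurement at hand accounts for these steps.

The step between compound 3 and compound 4 changes both the halogen and its place on the phenyl ring, so neither change can be read alone. On these data alone, whether the drop from compound 2 is confined to halogens stays open, as a methoxy group or an amine on this phenyl ring would test.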